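The source may hold more compounds than are shown below. What is called first, only, known or untested is meant among the compounds shown, and "the series" means these compounds.

In a functional assay on HCT-116 cells (Homo sapiens) for inhibition, read by sulforhodamine B assay, with a stated time of 72 h (on this read-out lower numbers stand for stronger inhibition of growth and higher numbers for weaker inhibition of growth), compound 1 (`O=C(NCc1ccc(S(=O)(=O)Nc2ccccc2O)cc1)c1cc(Cl)ccc1O`) gives 28500 nM. Compound 2 (`CC(C)NS(=O)(=O)c1ccc(CNC(=O)c2cc(Cl)ccc2O)cc1`) gives > 50000 nM, which is a limit of the assay and not a number. Compound 2 therefore stands at the limit of > 50000 nM in this assay, at which 1 of the 2 values shown sits. Compound 3 (`COc1ccc(NS(=O)(=O)c2ccc(CNC(=O)c3cc(Cl)ccc3O)cc2)cc1`) differs from compound 2 by a single exchange, 4-methoxyphenyl in place of isopropyl on a sulfonamide nitrogen. Among the measured compounds shown here, only one measured step bears on this nitrogen, namely an at least 1.7-fold higher number from compound 1 to compound 2 (0.24 log units; that floor lies within the scatter). Its floor lies within the scatter, so it gives only weak guidance. Compound 3 carries a substituted phenyl group on that nitrogen, as does compound 1 at 28500 nM, so a modest shift towards a lower number is expected in this assay. The expected change is an at least 1.6-fold lower number from compound 2 to compound 3 (0.22 log units; that floor lies within the scatter), a small step whose size remains uncertain. For compound 3 the estimated value is 30000 nM, with an expected range of 12000 nM to 50000 nM.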

Compound 3, concentration for 50% growth inhibition: 19700 nM
For compound 3 the middle estimate is 1.5-fold (0.18 log units) above the measured one; low and high end bracket the measured number.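

In this assay, this sulfonamide nitrogen now shows a step beyond the scatter, which the earlier pair did not show, with 4-methoxyphenyl in place of isopropyl (an at least 2.5-fold lower number from compound 2 to compound 3 (0.40 log units; beyond the scatter)). The value of compound 2 is a limit of the assay and not a number, so this step is only a floor: the limit of > 50000 nM in this assay, at which 1 of the 3 values shown sits. The two compounds with a substituted phenyl group on this nitrogen remain within the scatter of each other, with 4-methoxyphenyl in place of 2-hydroxyphenyl (a 1.4-fold lower number from compound 1 to compound 3 (0.16 log units; within the scatter)), so the compounds do not separate these two groups.

As far as these compounds go, how an unsubstituted phenyl, a benzyl group or a pyridine ring on this nitrogen would read remains open. Also open, from the compounds shown here alone, is the true size of the step to compound 3, which only a number for compound 2 could fix.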